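The source may hold more compounds than are shown below. What is called first, only, known or untested is meant among the compounds shown, and "the series" means these compounds.

In an ADME assay on microsomes from liver (Mus musculus, strain CD-1) for metabolic stability, read by HPLC, using NADPH (on this read-out lower numbers stand for a shorter-lived compound and higher numbers for a longer-lived compound), compound 1 `COc1ccc(NC(=O)[C@H]2c3ccccc3C(=O)N(CC(C)C)[C@@H]2c2cccs2)cc1Cl` gives 0.5 h. Compound 2 `CC(C)CN1C(=O)c2ccccc2[C@H](C(=O)Nc2ccc(F)c(C#N)c2)[C@H]1c1ccc(C#N)s1` gives 1.21 h in this assay, the higher of the two numbers shown. Compound 3 `CC(C)CN1C(=O)c2ccccc2[C@H](C(=O)Nc2ccc(F)c(C#N)c2)[C@H]1c1cn[nH]c1` differs from compound 2 in one place: 1H-pyrazol-4-yl in place of 5-cyanothiophen-2-yl on a saturated ring carbon. For the measured compounds named here, no pair of measured compounds shows this kind of change, so nothing measured here tells its size. The step is expected to be small, possibly within the scatter of this assay, with a slight lean toward a shorter half-life. The step expected in this assay is a 1.3-fold lower number from compound 2 to compound 3 (0.13 log units; within the scatter). The estimate for compound 3 is 0.9 h, with a range from 0.4 h to 2.2 h.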

Compound 3, half-life: 0.33 h
Beside the measured number, compound 3's estimate is 2.7-fold (0.44 log units) above it, outside the stated range (below it).
By their numbers in this assay, from the lowest: compounds 3 and 1 (each within the scatter of the next); then compound 2.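

At this saturated ring carbon, 1H-pyrazol-4-yl in place of 5-cyanothiophen-2-yl gives a 3.7-fold lower number from compound 2 to compound 3 (0.56 log units; beyond the scatter) in this assay and so shortens the half-life by more than the scatter. For the compounds shown here, this is the first pair to show that the half-life here is sensitive to exchanging one five-membered aromatic ring for another. No evidence on the cause of this step is available. Still open, on these data alone, is which part of the change carries the step, the nitrile or the ring itself. A 1-methyl-1H-pyrazol-4-yl group at this carbon, set beside compound 3, would test whether the pyrazole ring hydrogen plays a part.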